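Swapping a halogen on the fused core of compound 3

This account rests on a few compounds, and the source may have more. Where it says the series, first, only, none or still open, it means among the compounds named here.

Measured compounds:
Compound 1, `Clc1cc(Cl)c2[nH]cc(-c3ccc4ccccc4n3)c2c1`: 2.57 h
Compound 2, `Cc1cc(F)cc2c(-c3ccc4ccccc4n3)c[nH]c12`: 1.1 h
Compound 3, `Fc1cc(F)c2[nH]cc(-c3ccc4ccccc4n3)c2c1`: 0.45 h

In an ADME assay on microsomes from liver (Homo sapiens) for metabolic stability, using NADPH, with a stated time of 40 min, tested at 2 uM (on this read-out lower numbers stand for a shorter-lived compound and higher numbers for a longer-lived compound), compound 3 gives 0.45 h, the lowest of the three numbers. Its nearest neighbour is compound 2 at 1.1 h, and compound 1 at 2.57 h stands furthest from it. Among the compounds with values here, the only single-place step in this set is a 2.4-fold lower number from compound 2 to compound 3 (0.39 log units; beyond the scatter), which shows that exchanging one small group on the fused core moved this assay by a modest but real amount.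

Compound 4, `Fc1cc(Cl)cc2c(-c3ccc4ccccc4n3)c[nH]c12`, arises from compound 3 by chloro in place of fluoro on an aromatic carbon. Within the data shown here, no measured step covers this exact change, so it can only be read against what the values of compound 1 and compound 3 show: these two compounds differ in two places of the same kind, and compound 1 sits far higher. One such exchange is therefore expected to carry part of that gap, a moderate rise in this assay rather than the full distance, with the size of a 2.4-fold lower number from compound 2 to compound 3 (0.39 log units; beyond the scatter) as a guide to what one exchange can do.

For compound 4 the expected value is 1 h, with a range from 0.5 h to 2 h, meaning an estimated step of a 2.2-fold higher number from compound 3 to compound 4 (0.35 log units; beyond the scatter).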

Compound 4, half-life: 0.633 h
Compound 4: the middle estimate sits 1.6-fold (0.20 log units) above what was measured; low and high end bracket the measured number.
By their numbers in this assay, from the lowest: compounds 3, 4 and 2 (each within the scatter of the next, the first and the last beyond it); then compound 1.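

In this assay, exchanging fluoro for chloro at this place, on the carbon para to a fused ring, gives a 1.4-fold higher number from compound 3 to compound 4 (0.15 log units; within the scatter). Within the data shown here, this is the first direct reading of this position, and it shows that with the other fluoro group held constant, this exchange does not move the half-life beyond the usual scatter. The reverse exchange on the carbon bearing that other fluoro group gives a 4.1-fold lower number from compound 1 to compound 4 (0.61 log units; beyond the scatter), so the same pair of halogens matters at one of these carbons and not measurably at the other, and no available evidence accounts for that difference.

The compounds shown leave open whether a group of another kind at this place, such as methoxy, nitrile or an amine, would shift the half-life beyond the scatter or leave it as flat as chloro and fluoro do. They also leave open whether the contrast between the two carbons would persist on a core bearing a hydroxyl or a carboxylic acid elsewhere.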